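Cyclopropyl analogue with the amide chain: expectation

A few compounds are considered here, and "the series" means these few. Any claim that something is new, unique, unknown or untested is made for them only; others in the source may bear on it.

Measured compounds:
compound 1 `O=C(NCCCNc1ccnc(Nc2cccc(NC(=O)N3CCCC3)c2)n1)C1CCC1` — 2310 nM
compound 2 `O=C(NCCCNc1nc(Nc2cccc(NC(=O)N3CCCC3)c2)ncc1Br)C1CCC1` — 4.47 nM
compound 3 `NS(=O)(=O)c1ccc(CNc2nc(Nc3cccc(NC(=O)N4CCCC4)c3)ncc2C2CC2)cc1` — > 10000 nM (limit)

In an assay on HEK293 cells for displacement of a labelled ligand from serine/threonine-protein kinase 17A (Homo sapiens), read by NanoBRET (on this read-out lower numbers stand for stronger inhibition and higher numbers for weaker inhibition), compound 1 gives 2310 nM and compound 2 gives 4.47 nM. Compound 3 gives only a limit of the assay, > 10000 nM, so its standing among the numbers is open; (the limit of > 10000 nM in this assay, at which 1 of the 3 values shown sits). Among the compounds with values here, the single measured step, a 520-fold lower number from compound 1 to compound 2 (2.71 log units; beyond the scatter), changes the substituent on the aromatic carbon and leaves the chain untouched; it bears on the present step only in showing that the shared core with the cyclobutylcarbonyl chain can reach low numbers. Compound 4 `O=C(NCCCNc1nc(Nc2cccc(NC(=O)N3CCCC3)c2)ncc1C1CC1)C1CCC1` carries 2-((cyclobutylcarbonyl)amino)ethyl in place of 4-sulfamoylphenyl on a saturated chain carbon bound to a nitrogen on an aromatic ring. It thus combines the chain of compound 2 with the cyclopropyl of compound 3. Given that compound 3 stands at the limit > 10000 nM, the expected step of an at least 330-fold lower number from compound 3 to compound 4 (2.52 log units; beyond the scatter) is a drop in number, estimated as large, though its exact size cannot be read from a limit. Compound 4 in this assay is expected at 30 nM, with a range from 3 nM to 300 nM.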

Compound 4, half-maximal inhibitory concentration in the serine/threonine-protein kinase 17A assay: 58.2 nM
Beside the measured number, compound 4's estimate is 1.9-fold (0.29 log units) below it; the range from low to high includes it.
By their numbers in the serine/threonine-protein kinase 17A assay, from the lowest: compound 2; then compound 4; then compound 1. At a limit, above all of these: compound 3.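

In the serine/threonine-protein kinase 17A assay, with the 3-((cyclobutylcarbonyl)amino)propyl chain held fixed, cyclopropyl on the aromatic carbon gives a 40-fold lower number from compound 1 to compound 4 (1.60 log units; beyond the scatter) and a 13-fold higher number from compound 2 to compound 4 (1.11 log units; beyond the scatter), so on this chain the numbers run from lowest to highest as bromo, cyclopropyl, hydrogen. With cyclopropyl held fixed, the change of chain gives an at least 170-fold lower number from compound 3 to compound 4 (2.23 log units; beyond the scatter), which shows that a cyclopropyl compound can reach a low number with this chain, though not with 4-sulfamoylbenzyl. In the serine/threonine-protein kinase 17A assay compound 3 gives > 10000 nM, which is a limit, so that step gives only a bound: the limit of > 10000 nM in the serine/threonine-protein kinase 17A assay, at which 1 of the 4 values shown sits.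

Still open, on these data alone, is whether chloro or trifluoromethyl on the same aromatic carbon would match bromo, and whether a longer chain or one ending in an amine would keep the low number. In a physicochemical assay for solubility, in phosphate buffer, measured as kinetic solubility, with a stated time of 24 h, at pH 7.4 (on this read-out higher numbers stand for higher solubility and lower numbers for lower solubility), compound 3 gives 164000 nM and compound 4 gives 164000 nM. As far as these compounds go, in the physicochemical assay the change of chain shows no change at the digits printed from compound 3 to compound 4 (within the scatter), so any bearing of the aromatic substituent on that read-out remains open.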